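Cyclopentyl for methyl on the sulfur of compound 2

This account rests on a few compounds, and the source may have more. Where it says the series, first, only, none or still open, it means among the compounds named here.

The values in an ADME assay on MOLT-3 cells (Homo sapiens) for cytotoxicity, with a stated time of 7 days (a higher number here means that more compound is tolerated, a lower number that less compound is tolerated), so far are these.
- compound 1 `Nc1nc(N2CCCC2)c2ncn(/C=C3/CC3(CO)CO)c2n1` gives "not determined" (no result reported)
- compound 2 `CSc1nc(N)nc2c1ncn2/C=C1/CC1(CO)CO` gives > 20000 nM

Compound 1 offers no result to compare. In this assay compound 2 stands at > 20000 nM as a limit of the assay, not a number. Going by the values given here, the pair therefore holds no single number, and the series has no measured step to scale from.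

The next compound is compound 3 `Nc1nc(SC2CCCC2)c2ncn(/C=C3/CC3(CO)CO)c2n1`, which carries cyclopentyl in place of methyl on a sulfur. Methylsulfanyl thus becomes cyclopentylsulfanyl.

The estimated step of an at least 1.2-fold lower number from compound 2 to compound 3 (0.09 log units; that floor lies within the scatter) is small, quite possibly within the scatter, and is expected to lean toward less compound being tolerated. This expectation rests only on the structural change and on compound 2 at > 20000 nM as a limit. A report of a limit alone is also expected to be quite possible. For compound 3 the estimated value of 16000 nM carries an expected range of 5000 nM to 50000 nM in this assay once measured.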

Compound 3, half-maximal cytotoxic concentration: > 20000 nM
Compound 3: no number, only a limit; the forecaster's own chance of this, stated with the estimate: 55%; middle value at least 1.2-fold (0.09 log units) from the limit.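

In this assay compound 3 gives > 20000 nM, a limit and not a number. Compound 2 also reads as a limit, so no step can be read between compound 2 and compound 3: the limit of > 20000 nM in this assay, at which 2 of the 3 values shown sit. Still open, on these data alone, is whether cyclopentyl in place of methyl on a sulfur shifts the value in this assay at all.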